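The compounds below may be only part of what the source reports. "The series", "measured", "known", "first", "only" and "open" are said of these compounds alone.

Measured so far in a functional assay on QGY-7703 cells (Homo sapiens) for cytotoxicity, read by MTT assay, with a stated time of 24 h; a lower number here means a stronger inhibitor, a higher number a weaker inhibitor:

Compound 1 `CN1C/C(=C\c2ccncc2)C(=O)/C(=C/c2ccccc2C(F)(F)F)C1`: 4500 nM
Compound 2 `O=C1/C(=C/c2ccncc2)CN(S(=O)(=O)c2ccc([N+](=O)[O-])cc2)C/C1=C\c1ccccc1C(F)(F)F`: 9730 nM

Compound 2 holds the higher of these two numbers, so it is the weaker inhibitor of the pair. Compound 3 `N#Cc1ccc(S(=O)(=O)N2C/C(=C\c3ccncc3)C(=O)/C(=C/c3ccccc3C(F)(F)F)C2)cc1` departs from it at one place: cyano in place of nitro on an aromatic carbon. Within the data shown here, no measured step makes this exchange. Among the measured compounds shown here, the only step at hand is a 2.2-fold higher number from compound 1 to compound 2 (0.33 log units; beyond the scatter). That modest step replaced the whole substituent on the ring nitrogen, so it bears on the present change only indirectly. Nothing measured therefore points to a direction in this assay, and no step beyond the scatter is expected. The expected change is a 1.2-fold lower number from compound 2 to compound 3 (0.09 log units; within the scatter). For compound 3 the estimated value is 8000 nM, with an expected range of 3500 nM to 18000 nM.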

Compound 3, half-maximal inhibitory concentration: 6290 nM
Estimate against measurement, compound 3: 1.3-fold (0.10 log units) above; the measured number falls inside the stated range.
By their numbers in this assay, from the lowest: compounds 1, 3 and 2 (each within the scatter of the next, the first and the last beyond it).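

In this assay, putting cyano in place of nitro on an aromatic carbon, para to a large group, gives a 1.5-fold lower number from compound 2 to compound 3 (0.19 log units; within the scatter), so the two groups cannot be told apart at this position in this assay. The exchange of methyl on the ring nitrogen for (4-cyanophenyl)sulfonyl gives a 1.4-fold higher number from compound 1 to compound 3 (0.15 log units; within the scatter), whereas the exchange for (4-nitrophenyl)sulfonyl gave a 2.2-fold higher number from compound 1 to compound 2 (0.33 log units; beyond the scatter), so an arylsulfonyl group on that nitrogen does not always move the number beyond the scatter. Nothing available here accounts for these readings.

The compounds shown leave open whether an amine or a carboxylic acid at this same aromatic carbon would also stay within the scatter of nitro and cyano. They also leave open how a plain phenylsulfonyl group or a longer alkyl chain on the ring nitrogen would read.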